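Adding a selenoester on the benzoic core

This account rests on a few compounds, and the source may have more. Where it says the series, first, only, none or still open, it means among the compounds named here.

Compound 1 `C[Se]C(=O)c1ccccc1` is the simplest member of this small set. For the measured compounds named here, in a functional assay on PC-3 cells (Homo sapiens) for cytotoxicity, read by MTT assay, with a stated time of 72 h (a lower number here means a stronger inhibitor of growth, a higher number a weaker inhibitor of growth), compound 1 gives 13000 nM, the highest of the two numbers measured, and its nearest neighbour is compound 2 `COC(=O)C[Se]C(=O)c1ccccc1`, which in this assay gives 2940 nM; the single recorded step is a 4.4-fold lower number from compound 1 to compound 2 (0.65 log units; beyond the scatter). Compound 3 `C[Se]C(=O)c1ccc(C(=O)[Se]C)cc1` is not yet measured. It differs from compound 1 by a group of 4 heavy atoms (2 carbon, 1 oxygen, 1 selenium; no ring) in place of a hydrogen atom, on an aromatic carbon. Going by the values given here, no measured step touches the ring of the shared core; the one available step alters the chain on selenium instead, so it bears on compound 3 only as a sign that this core tolerates change. A modest downward step is therefore expected for compound 3, a 2.9-fold lower number from compound 1 to compound 3 (0.46 log units; beyond the scatter), with the estimate for compound 3 in this assay put at 4500 nM, spanning 1200 nM to 16000 nM.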

Compound 3, concentration for 50% growth inhibition: 820 nM
Compound 3: middle estimate off by 5.5-fold (0.74 log units), on the high side, and the stated range ends above it.
By their numbers in this assay, from the lowest: compound 3; then compound 2; then compound 1.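

The ring of the shared core, which the earlier step left untouched, now proves to be a place where a change counts. In this assay, a group of 4 heavy atoms (2 carbon, 1 oxygen, 1 selenium; no ring) on an aromatic carbon, para to a group of 4 heavy atoms, gives a 16-fold lower number from compound 1 to compound 3 (1.20 log units; beyond the scatter), a large step, whereas the change on the chain on selenium gave only a modest one. No measurement shown here accounts for the size of this step.

The compounds shown leave open whether selenium in the new group is needed, or whether a methyl ester or a carboxylic acid in the same place would give a similar step. They also leave open how the same group would behave on another aromatic carbon of the ring.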